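Pyridin-2-yl for trifluoromethylphenyl on a second core

This account rests on a few compounds, and the source may have more. Where it says the series, first, only, none or still open, it means among the compounds named here.

Compound 1, `C=C1C(=O)[C@]23C[C@@]1(O)CC[C@H]2c1ccc(O)c(C)c1[C@@H]3Cn1cc(-c2ccccn2)nn1`, gives 2240 nM in a functional assay on MCF7 cells (Homo sapiens) for cytotoxicity, read by MTT assay, with a stated time of 4 days; on this read-out lower numbers stand for stronger inhibition and higher numbers for weaker inhibition.
Compound 2, `C=C1C(=O)[C@]23C[C@@]1(O)CC[C@H]2c1ccc(O)c(C)c1[C@@H]3Cn1cc(-c2ccc(C(F)(F)F)cc2)nn1`, gives 1840 nM in this assay.
Compound 3, `C=C1C[C@]23C[C@@]1(O)CC[C@H]2c1ccc(OS(=O)(=O)c2ccc(C)cc2)c(C)c1[C@@H]3Cn1cc(-c2ccc(C(F)(F)F)cc2)nn1`, reaches only a limit of this assay, > 20000 nM.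

Compound 1 differs from compound 2 by pyridin-2-yl in place of 4-(trifluoromethyl)phenyl on an aromatic carbon. The measured step is a 1.2-fold higher number from compound 2 to compound 1 (0.09 log units; within the scatter). Compound 3 shares its core with the unmeasured compound 4, `C=C1C[C@]23C[C@@]1(O)CC[C@H]2c1ccc(OS(=O)(=O)c2ccc(C)cc2)c(C)c1[C@@H]3Cn1cc(-c2ccccn2)nn1`; how that core differs from the core of compound 2 is not broken down here. Among the compounds with values here, compound 4 differs from compound 3 by pyridin-2-yl in place of 4-(trifluoromethyl)phenyl on an aromatic carbon, and this is the same change as the one from compound 2 to compound 1, made at the same place. For compound 3 this assay reports only a limit, (the limit of > 20000 nM in this assay, at which 1 of the 3 values shown sits), so no number stands at the start of the second step. Because the step of a 1.2-fold higher number from compound 2 to compound 1 (0.09 log units; within the scatter) stayed within the scatter, the step that the limit leaves unreadable from compound 3 to compound 4 is expected to be small as well. Compound 4 is therefore expected to stay at or beyond the limit of this assay, with an estimated value of about 30000 nM, between 10000 nM and 100000 nM.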

Compound 4, half-maximal inhibitory concentration: > 20000 nM
Compound 4 ended at the assay's limit; the forecaster's own chance of this, stated with the estimate: 70%; the middle value does not contradict the limit.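

Compound 3 and compound 4 both sit at a limit of this assay, not at a number, so the exchange of 4-(trifluoromethyl)phenyl for pyridin-2-yl yields no readable step between them: the limit of > 20000 nM in this assay, at which 2 of the 4 values shown sit.

The compounds shown leave open how far past that limit either compound lies, and whether this exchange has any effect on their shared core.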